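From Ethoxycarbonyl to Benzyloxycarbonyl: Expecting a Lower Number

The compounds below may be only part of what the source reports. "The series", "measured", "known", "first", "only" and "open" are said of these compounds alone.

In an ADME assay on HeLa cells (Homo sapiens) for cytotoxicity, read by MTT assay, with a stated time of 2 days (a higher number here means that more compound is tolerated, a lower number that less compound is tolerated), compound 1 (`CCOC(=O)c1cc2ccc(Oc3ccnc(C(=O)NC)c3)cc2s1`) gives > 100000 nM as a limit of the assay and not a number. Compound 2 (`CCOC(=O)c1sc2cc(Oc3ccnc(C(=O)NC)c3)ccc2c1C`) gives > 100000 nM as a limit too. Compound 2 thus stands at the limit of > 100000 nM in this assay, at which 2 of the 3 values shown sit, and has no readable number. Compound 3 (`CNC(=O)c1cc(Oc2ccc3c(C)c(C(=O)OC(C)C)sc3c2)ccn1`) gives 9600 nM as a measured number.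

Compound 4 (`CNC(=O)c1cc(Oc2ccc3c(C)c(C(=O)OCc4ccccc4)sc3c2)ccn1`) is reached from compound 2 by the change phenyl in place of methyl on a saturated chain carbon bound to an oxygen next to a carbonyl group in which phenyl takes the place of methyl on a saturated chain carbon bound to an oxygen next to a carbonyl group, so that ethoxycarbonyl becomes benzyloxycarbonyl.

Methyl in place of hydrogen on an aromatic carbon is a step that the two limits leave unreadable from compound 1 to compound 2 and offers no guide. Methyl in place of hydrogen on a saturated chain carbon bound to an oxygen next to a carbonyl group and a saturated chain carbon is an at least 10-fold lower number from compound 2 to compound 3 (1.01 log units; beyond the scatter) and bears on compound 4 as the one readable step at the same place. That single large step points towards less compound being tolerated. The estimated change is an at least 5.0-fold lower number from compound 2 to compound 4 (0.69 log units; beyond the scatter) and is expected to be downward in this assay but with its size uncertain. For compound 4 the expected value is 20000 nM with an estimated range from 5000 nM to 100000 nM as its two ends.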

Compound 4, half-maximal cytotoxic concentration: 18100 nM
Compound 4: the middle estimate sits 1.1-fold (0.04 log units) above what was measured; low and high end bracket the measured number.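

Phenyl in place of methyl on a saturated chain carbon bound to an oxygen next to a carbonyl group gives an at least 5.5-fold lower number from compound 2 to compound 4 (0.74 log units; beyond the scatter) in this assay, so a second change at this place, not only the one that led to compound 3, moves the number down. Benzyl in place of isopropyl on an oxygen next to a carbonyl group gives a 1.9-fold higher number from compound 3 to compound 4 (0.28 log units; within the scatter), which lies within the scatter, so compound 3 and compound 4 cannot be told apart here even though only the group entering compound 4 carries a six-membered aromatic ring of carbon only. The size of the drop from compound 2 remains only a bound, since that step starts from a limit and not from a number: the limit of > 100000 nM in this assay, at which 2 of the 4 values shown sit.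

The compounds shown leave open whether a carboxylic acid or a longer chain in place of ethoxycarbonyl would also lower the number or would leave it at the limit. As far as these compounds go, whether methyl on the aromatic carbon plays any part in the number of compound 4 also stays open; the step from compound 1 to compound 2 cannot be read.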